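The source may hold more compounds than are shown below. What is called first, only, known or untested is meant among the compounds shown, and "the series" means these compounds.

Measured so far:
compound 1 `Cc1cccc(-c2noc([C@H](C)NC(=O)c3cc(C4CC4)nn3C)n2)c1` — 167 nM
compound 2 `Cc1cccc(-c2noc([C@H](C)NC(=O)c3cc(C4CC4)n(C)n3)n2)c1` — > 30000 nM
compound 3 `Cc1cccc(-c2noc([C@H](C)NC(=O)c3cc(C(F)(F)F)nn3C)n2)n1` — > 30000 nM

In an assay on T-REx-293 cells for inhibition of potassium channel subfamily T member 1 (Homo sapiens), read by patch clamp (a lower number here means a stronger inhibitor, a higher number a weaker inhibitor), compound 1 gives 167 nM. For compound 2 the result is only a limit, > 30000 nM. For compound 3 the result is likewise only a limit, > 30000 nM. For the measured compounds named here, compound 3 thus stands at the limit of > 30000 nM in this assay, at which 2 of the 3 values shown sit, with no number of its own, so no step to it can be sized.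

Compound 4 `Cc1ccnc(-c2noc([C@H](C)NC(=O)c3cc(C(F)(F)F)nn3C)n2)c1` is not yet measured. It differs from compound 3 by 4-methylpyridin-2-yl in place of 6-methylpyridin-2-yl on an aromatic carbon. No step between measured compounds bears on this change, and compound 3 itself has no number, so the direction of the step from compound 3 to compound 4 cannot be read from what is shown; it is expected to stay near the limit, with a moderate chance of a measurable value. Compound 4 is estimated at 20000 nM (range 3000 nM to 60000 nM), corresponding to the expected step of an at least 1.5-fold lower number from compound 3 to compound 4 (0.17 log units; that floor lies within the scatter).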

Compound 4, half-maximal inhibitory concentration: 4470 nM
Estimate against measurement, compound 4: 4.5-fold (0.65 log units) above; the range from low to high includes it.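

In this assay, 4-methylpyridin-2-yl in place of 6-methylpyridin-2-yl gives an at least 6.7-fold lower number from compound 3 to compound 4 (0.82 log units; beyond the scatter), so this position on the shared core responds to where the methyl sits, with the atom count unchanged. For the compounds shown here, compound 4 also gives the first measured value here for a compound that carries trifluoromethyl. The value of compound 3 is a limit and not a number, so the true size of the step stays unknown: the limit of > 30000 nM in this assay, at which 2 of the 4 values shown sit.

From the compounds shown here alone, it remains open how far a methoxy group or a chlorine atom in place of the methyl would move the value. Also open, going by these compounds, is whether 4-methylpyridin-2-yl gives a similar result with cyclopropyl in place of trifluoromethyl.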